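One more side group on a shared core

A few compounds are considered here, and "the series" means these few. Any claim that something is new, unique, unknown or untested is made for them only; others in the source may bear on it.

In a functional assay on SNB-19 cells (Homo sapiens) for inhibition, read by MTT assay, with a stated time of 7 days (on this read-out lower numbers stand for stronger inhibition of growth and higher numbers for weaker inhibition of growth), compound 1 `C#CCn1nnc2c(C(N)=O)ncn2c1=O` gives 35600 nM. Compound 2 `NC(=O)c1ncn2c(=O)n(Cc3ccco3)nnc12` gives > 50000 nM, which is a limit of the assay and not a number. Compound 3 `NC(=O)c1ncn2c(=O)n(Cc3ccsc3)nnc12` gives > 50000 nM, which is also a limit. Compound 3 therefore stands at the limit of > 50000 nM in this assay, at which 2 of the 3 values shown sit, so its true value is not known.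

Compound 4 `Cc1noc(Cn2nnc3c(C(N)=O)ncn3c2=O)n1` keeps the core of compound 3 and changes one group, on a saturated chain carbon bound to an aromatic nitrogen: 3-methyl-1,2,4-oxadiazol-5-yl in place of thiophen-3-yl on a saturated chain carbon bound to an aromatic nitrogen. Three measured steps at this same place bear on the change. Putting a five-membered aromatic ring in place of ethynyl gives an at least 1.4-fold higher number from compound 1 to compound 2 (0.14 log units; that floor lies within the scatter) with furan-2-yl and an at least 1.4-fold higher number from compound 1 to compound 3 (0.14 log units; that floor lies within the scatter) with thiophen-3-yl. The exchange closest to the new one, a swap of one such ring for another, gives a step that the two limits leave unreadable from compound 2 to compound 3.

Going by the values given here, none of these steps shows a change beyond the scatter, so no step of that size is expected in this assay, in either direction. Growth inhibition is expected to stay weak, and the assay may again report only a limit. The expected step is a number no higher from compound 3 to compound 4 (the limit leaves the size open). The estimate for compound 4 is 50000 nM, with an expected range from 25000 nM to 100000 nM.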

Compound 4, concentration for 50% growth inhibition: > 50000 nM
Compound 4 was reported as a limit; the forecaster's own chance of this, stated with the estimate: 70%; the middle value sits exactly at the limit.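

In this assay, compound 4 is reported only as a limit and not as a number, like compound 2 and compound 3, so the steps among these three compounds cannot be read. Going by these compounds alone, the one step that can be read is an at least 1.4-fold higher number from compound 1 to compound 4 (0.14 log units; that floor lies within the scatter). This extends the picture to a third five-membered aromatic ring at this place, one with three hetero atoms and three hydrogen-bond acceptors where thiophen-3-yl has one hetero atom and one acceptor, and even this larger change in ring make-up yields no number, only the same limit: the limit of > 50000 nM in this assay, at which 3 of the 4 values shown sit.

The true values of compound 2, compound 3 and compound 4 are not known, so the compounds shown cannot tell whether these rings differ from one another or whether any of them truly differs from the ethynyl group of compound 1. From the compounds shown here alone, it also remains open whether a group of another kind on this saturated chain carbon, such as an amine, a carboxylic acid or a longer alkyl chain, would give a measured number rather than a limit.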